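A Propargyl Piperidine Step Beyond the Assay Ceiling

A few compounds are considered here, and "the series" means these few. Any claim that something is new, unique, unknown or untested is made for them only; others in the source may bear on it.

Compound 1, `CC(C)c1ccc(NC(=O)OCC2CCN(Cc3ccccc3)CC2)cc1`: > 100000 nM
Compound 2, `CC(C)c1ccc(NC(=O)OCC2CCCN(Cc3ccccc3)C2)cc1`: > 100000 nM
Compound 3, `C#CCN1CCC(O)CC1`: > 100000 nM

In an assay on BTI-TN-5B1-4 cells for inhibition of Amine oxidase [flavin-containing] A (Homo sapiens), read by fluorescence and Amplex Red, using microsomes, with a stated time of 15 min (on this read-out higher numbers stand for weaker inhibition and lower numbers for stronger inhibition), compound 1 gives > 100000 nM, which is a limit of the assay and not a number. Compound 2 likewise gives > 100000 nM, again only a limit. Compound 3 gives > 100000 nM, a limit as well. Nothing in these figures orders the three compounds, because the limit of > 100000 nM in this assay, at which 3 of the 3 values shown sit, shows that every value sits at the same ceiling; compound 3 is therefore neither stronger nor weaker than the others on the numbers shown, and no step between two measured compounds can be drawn.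

The unmeasured compound 4, `C#CCN1CCC(CO)CC1`, departs from compound 3 by hydroxymethyl in place of hydroxy on a saturated ring carbon, three ring bonds from the ring nitrogen that bears the propargyl group.

Among the compounds with values here, with every measured value at the limit, there is no step on record that would argue for a change in either direction, and the one added carbon gives no footing for one. The step from compound 3 to compound 4 is expected to be a step that the limit leaves unreadable from compound 3 to compound 4, nothing beyond the usual scatter. Compound 4 is accordingly estimated at 150000 nM, within 40000 nM to 600000 nM, and most probably the assay would again report only a limit.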

Compound 4, half-maximal inhibitory concentration: > 100000 nM
Compound 4 was reported as a limit; the forecaster's own chance of this, stated with the estimate: 85%; the middle value is on the limit's open side.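

In this assay compound 4 gives > 100000 nM, which is a limit of the assay and not a number. No step can be read from compound 3 to compound 4, because both values are limits: the limit of > 100000 nM in this assay, at which 4 of the 4 values shown sit.

The compounds shown leave open how hydroxymethyl and hydroxy compare in this assay, and whether any of these structures has a value that can be read as a number.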